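Methyl in Place of Fluoro on the Aromatic Ring

The source may hold more compounds than are shown below. What is called first, only, known or untested is meant among the compounds shown, and "the series" means these compounds.

In an assay on isolated protein for inhibition of long-chain fatty acid transport protein 1 (Homo sapiens) (on this read-out higher numbers stand for weaker inhibition and lower numbers for stronger inhibition), compound 1 `CCn1c(CNc2ccccc2)nnc1SCc1nc2cc(C(=O)C(C)C)ccc2o1` gives 600 nM. Compound 2 `CCn1c(CNc2ccccc2)nnc1SCc1nc2cc(F)ccc2o1` reaches only the limit of > 1000 nM in this assay, a boundary of the measurement rather than a number (the limit of > 1000 nM in this assay, at which 1 of the 2 values shown sits). Among the measured compounds shown here, the single measured step, an at least 1.6-fold higher number from compound 1 to compound 2 (0.22 log units; that floor lies within the scatter), is therefore known only as a floor and is the one step that bears on what follows. Compound 3 `CCn1c(CNc2ccccc2)nnc1SCc1nc2cc(C)ccc2o1` carries the change (methyl in place of fluoro on an aromatic carbon). Both groups entering and leaving are single heavy atoms, so only a small shift is expected for compound 3, a step that the limit leaves unreadable from compound 2 to compound 3. Compound 3 is estimated at 1500 nM, between 600 nM and 4000 nM.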

Compound 3, half-maximal inhibitory concentration: > 1000 nM
Compound 3: a limit, no number (the forecaster's own chance of this, stated with the estimate: 55%); the middle value lies beyond the limit too.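

Compound 3 also stops at a limit of the assay, > 1000 nM, and not at a number. Methyl in place of isopropylcarbonyl is known only as a floor, an at least 1.6-fold higher number from compound 1 to compound 3 (0.22 log units; that floor lies within the scatter), so a second small group joins fluoro in giving no readable number at this position. Methyl and fluoro cannot be ranked against each other, because the step between them cannot be read: the limit of > 1000 nM in this assay, at which 2 of the 3 values shown sit.

From the compounds shown here alone, how far either small group truly lies from isopropylcarbonyl stays open. Also open, going by these compounds, is whether a smaller carbonyl group such as acetyl, or a carboxylic acid, would give a measurable value on this aromatic carbon.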